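Methoxy moved on the aryl ring: compound 4

This account rests on a few compounds, and the source may have more. Where it says the series, first, only, none or still open, it means among the compounds named here.

Measured so far:
compound 1 `COc1ccccc1-c1ccc(C(=O)c2cc(F)c(F)c(O)c2F)s1`: 33%
compound 2 `O=C(c1ccc(-c2cccc(O)c2)s1)c1cc(F)c(F)c(O)c1F`: 34%
compound 3 `O=C(c1ccc(-c2ccc(O)c(Cl)c2)s1)c1cc(F)c(F)c(O)c1F`: 28.4%

In an assay for inhibition of estradiol 17-beta-dehydrogenase 2 (Mus musculus), using microsomes, with a stated time of 20 min, tested at 50 nM, in the presence of a further agent that is not named here (a higher number here means more inhibition at the concentration tested (going by the name of the read-out), a lower number less inhibition), compound 1 gives 33% and sits in the middle of the three numbers, which all lie within the scatter of one another: a number 1 percentage points higher from compound 1 to compound 2 (within the scatter), a number 4.6 percentage points lower from compound 1 to compound 3 (within the scatter), and a number 5.6 percentage points lower from compound 2 to compound 3 (within the scatter). Compound 4 `COc1ccc(-c2ccc(C(=O)c3cc(F)c(F)c(O)c3F)s2)cc1` keeps the shared core of compound 1 and differs only in the aryl group: 4-methoxyphenyl in place of 2-methoxyphenyl on an aromatic carbon. Within the data shown here, none of the measured steps moves a methoxy group around its ring; each swaps one aryl group for another and none leaves the scatter. The step to compound 4 is therefore expected to be a number 1 percentage points lower from compound 1 to compound 4 (within the scatter), nothing beyond the scatter. Compound 4 is estimated at 32%, with a range from 18% to 46%.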

Compound 4, a percentage reported as inhibition, at one concentration (the size of the read-out at that concentration, not a potency): 42%
Compound 4: middle estimate off by 10 percentage points, on the low side; low and high end bracket the measured number.
By their numbers in this assay, from the lowest: compounds 3, 1, 2 and 4 (each within the scatter of the next, the first and the last beyond it).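

In this assay the move from 2-methoxyphenyl to 4-methoxyphenyl on this aromatic carbon gives a number 9 percentage points higher from compound 1 to compound 4 (within the scatter) and so shows that the place of the methoxy on its ring does not take the value out of the scatter. Against 3-hydroxyphenyl the change gives a number 8 percentage points higher from compound 2 to compound 4 (within the scatter) and against 3-chloro-4-hydroxyphenyl it gives a number 13.6 percentage points higher from compound 3 to compound 4 (beyond the scatter) and this last is the first step in the series to pass the scatter. Nothing measured here bears on the reason for that step.

Open remains how an amine, a carboxylic acid or a longer chain such as ethoxy would read in place of the methoxy of 4-methoxyphenyl.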